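The source may hold more compounds than are shown below. What is called first, only, known or untested is meant among the compounds shown, and "the series" means these compounds.

Of the compounds shown here, two of a shared core have been tested in a functional assay on PC-3 cells (Homo sapiens) for cytotoxicity, read by MTT assay, with a stated time of 72 h; a lower number here means a stronger inhibitor, a higher number a weaker inhibitor. Compound 1 `O=C(Nc1ccc(Oc2ccnc3[nH]ccc23)cc1)c1ccc(-c2ccc(Cl)cc2)cn1` reaches only a limit of the assay, > 10000 nM, in this assay. For the measured compounds named here, compound 2 `Cc1ccc(-c2ccnc(C(=O)Nc3ccc(Oc4ccnc5[nH]ccc45)c(F)c3)c2)cc1` gives 3970 nM in this assay, and this is the only actual number among the values shown. The other value shown, that of compound 1, is a limit (the limit of > 10000 nM in this assay, at which 1 of the 2 values shown sits). Compound 3 `O=C(Nc1ccc(Oc2ccnc3[nH]ccc23)c(F)c1)c1cc(-c2ccc(C(F)(F)F)cc2)ccn1` is not yet measured; it differs from compound 2 by trifluoromethyl in place of methyl on an aromatic carbon. Going by the values given here, no step between two measured compounds is available to gauge such a change, so its size here is uncertain. A modest gain in potency is expected, so that the step from compound 2 to compound 3 is estimated at a 2.2-fold lower number from compound 2 to compound 3 (0.34 log units; beyond the scatter), though a result within the scatter would not surprise. For compound 3 in this assay a value of 1800 nM is expected, within a range from 500 nM to 7000 nM.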

Compound 3, half-maximal inhibitory concentration: 4350 nM
Compound 3: the middle estimate sits 2.4-fold (0.38 log units) below what was measured; low and high end bracket the measured number.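

For the compounds shown here, the step from methyl to trifluoromethyl gives the first reading of this position in this assay, on a six-membered aromatic ring of carbon only, para to a large group: a 1.1-fold higher number from compound 2 to compound 3 (0.04 log units; within the scatter). Going from 4-methylphenyl to 4-(trifluoromethyl)phenyl thus leaves the number unchanged within the scatter, and this one pair shows that at least this exchange does not separate the two compounds. Nothing among the data shown accounts for this flat result.

The compounds shown leave open whether an amine, a carboxylic acid or a longer chain at the same place would move the number in this assay. Going by these compounds alone, they also leave open whether this flat step would hold on another version of the shared core, since only one such pair is available.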